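This account rests on a few compounds, and the source may have more. Where it says the series, first, only, none or still open, it means among the compounds named here.

Compounds measured so far:
- compound 1, `COc1ccc(-c2cn3nc(Cl)sc3n2)cc1`: in a functional assay on L1210 cells (Mus musculus) for cytotoxicity, with a stated time of 48 h (a lower number here means a stronger inhibitor, a higher number a weaker inhibitor), compound 1 gives 38000 nM
- compound 2, `O=c1oc2ccccc2cc1-c1cn2nc(Cc3ccc(Cl)cc3)sc2n1`: for compound 2 only a limit of the assay is known, > 10000 nM
- compound 3, `O=c1oc2ccccc2cc1-c1nc2sc(Cc3ccc(Cl)cc3)nn2c1Br`: compound 3 gives 5200 nM

Among the two numbers, compound 3 holds the lower one, and the gap to compound 1 is beyond the usual scatter. Compound 4, `O=Cc1c(-c2cc3ccccc3oc2=O)nc2sc(Cc3ccc(Cl)cc3)nn12`, differs from compound 3 by formyl in place of bromo on an aromatic carbon. Among the measured compounds shown here, only one measured step touches this position: an at least 1.9-fold lower number from compound 2 to compound 3 (0.28 log units; that floor lies within the scatter). Its size is uncertain, resting on (the limit of > 10000 nM in this assay, at which 1 of the 3 values shown sits). For the measured compounds named here, no measured pair exchanges bromo for formyl, so no clear direction can be drawn. The expectation for compound 4 is therefore a number close to that of compound 3, with a 1.0-fold lower number from compound 3 to compound 4 (0.02 log units; within the scatter). Compound 4 is estimated at 5000 nM, with a range from 1500 nM to 16000 nM.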

Compound 4, half-maximal inhibitory concentration: 890 nM
Estimate against measurement, compound 4: 5.6-fold (0.75 log units) above; the whole stated range lies above it.
By their numbers in this assay, from the lowest: compound 4; then compound 3; then compound 1.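

In this assay, this position on the five-membered aromatic ring proves sensitive to the group it carries: formyl in place of bromo gives a 5.8-fold lower number from compound 3 to compound 4 (0.77 log units; beyond the scatter), whereas the earlier step from hydrogen to bromo could not be told from the scatter. Formyl in place of hydrogen gives an at least 11-fold lower number from compound 2 to compound 4 (1.05 log units; beyond the scatter). That size is only a floor, since compound 2 has just a limit: the limit of > 10000 nM in this assay, at which 1 of the 4 values shown sits.

Why formyl gives the lower number than bromo stays open. So does how an amine, a carboxylic acid or a longer chain would behave at this position.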